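The source may hold more compounds than are shown below. What is called first, only, known or untested is meant among the compounds shown, and "the series" means these compounds.

Among the compounds with values here, in a functional assay on A549 cells (Homo sapiens) for antiproliferative activity, read by MTT assay, with a stated time of 72 h (a higher number here means a weaker inhibitor, a lower number a stronger inhibitor), compound 1 (`CN(C)CCn1cccc1/C=N/NC(=O)Nc1ccc(Oc2ccnc3[nH]ccc23)cc1`) is reported as "not active" (no number reported) with no number given, and compound 2 (`CN(C)CCCn1cccc1/C=N/NC(=O)Nc1ccc(Oc2ccnc3[nH]ccc23)cc1`) gives 2660 nM as the only number available so far. Compound 3 (`O=C(N/N=C/c1cccn1CCCN1CCCCC1)Nc1ccc(Oc2ccnc3[nH]ccc23)cc1`) differs from compound 2 in one place: piperidin-1-yl in place of dimethylamino on a saturated chain carbon, three bonds along the chain from an aromatic nitrogen turns the 3-(dimethylamino)propyl chain into 3-(piperidin-1-yl)propyl. Within the data shown here, no measured pair shows this change, so no step beyond the usual scatter is expected in this assay and any lean is slight, toward stronger inhibition. The expected step of a 1.3-fold lower number from compound 2 to compound 3 (0.12 log units; within the scatter) is only an estimate. For compound 3 the estimated value is 2000 nM within an expected range of 800 nM to 5000 nM in this assay here.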

Compound 3, half-maximal inhibitory concentration: 1560 nM
Compound 3: middle estimate off by 1.3-fold (0.11 log units), on the high side; low and high end bracket the measured number.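

In this assay the swap of dimethylamino for piperidin-1-yl on the propyl chain gives a 1.7-fold lower number from compound 2 to compound 3 (0.23 log units; within the scatter) and so makes no readable difference. This position therefore takes the six-membered ring, with its larger heavy-atom count, and activity stays in the same range as with the open dimethylamino group. No evidence on the reason for this is available.

Still open, as far as these compounds go, is how a morpholin-4-yl or 4-methylpiperazin-1-yl group would read at this chain end. Also open, from the compounds shown here alone, is whether 2-(piperidin-1-yl)ethyl, on the shorter chain of compound 1, would show measurable activity.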